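Removing the carbamate from a methylated nucleoside

The source may report more compounds than this note shows. Statements on the series, on what has been measured and on what is new or still open speak of the compounds shown alone.

Three nucleoside analogues have been examined in an ADME assay on CCRF-CEM cells (Homo sapiens) for cytotoxicity, read by trypan blue exclusion, with a stated time of 6 days; a higher number here means that more compound is tolerated, a lower number that less compound is tolerated. Compound 1 `COc1nc(Cl)nc2c1ncn2[C@@H]1O[C@H](CO)[C@@H](O)[C@@]1(C)O` reaches only the limit of the method there, giving > 100000 nM. Compound 2 `C[C@@]1(O)[C@H](O)[C@@H](CO)O[C@H]1n1cnc2c(N)nc(N=[N+]=[N-])nc21` likewise returns only a limit, > 100000 nM. Compound 3 `COc1nc(ONC(=O)OCc2ccccc2)nc2c1ncn2[C@@H]1O[C@H](CO)[C@@H](O)[C@@]1(C)O` stands at a limit as well, with > 100000 nM. What is known of compound 3 in this assay is thus a limit and not a number, and the same picture holds across the whole set: the limit of > 100000 nM in this assay, at which 3 of the 3 values shown sit.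

Compound 4 `COc1nc(O)nc2c1ncn2[C@@H]1O[C@H](CO)[C@@H](O)[C@@]1(C)O` differs from compound 3 in a single place: hydrogen in place of (benzyloxycarbonyl)amino on an oxygen on an aromatic ring. Going by the values given here, no step between two measured compounds carrying this same change has been recorded, so the size expected for this assay can rest only on the fact that every measured compound sits at the limit. Compound 4 is therefore expected to show no shift beyond the usual scatter of this assay. The step from compound 3 to compound 4 is estimated as a step that the limit leaves unreadable from compound 3 to compound 4. Compound 4 is expected to give about 150000 nM, within a range from 50000 nM to 500000 nM, and the method is expected most often to report only a limit again.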

Compound 4, half-maximal cytotoxic concentration: > 100000 nM
Compound 4: only a limit was reported; the forecaster's own chance of this, stated with the estimate: 85%; the middle value does not contradict the limit.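

In this assay compound 4 gives > 100000 nM, which is a limit and not a number. The steps from compound 3 and from compound 1 to compound 4 therefore cannot be read: the limit of > 100000 nM in this assay, at which 4 of the 4 values shown sit.

The compounds shown leave open whether any change on the shared core alters the concentration tolerated in this assay.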